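A few compounds are considered here, and "the series" means these few. Any claim that something is new, unique, unknown or untested is made for them only; others in the source may bear on it.

Measured so far:
compound 1 `COc1ccccc1Oc1ccc2c(NCCCNCc3ccco3)ccnc2c1` — 317 10^-6 cm/s
compound 2 `COc1cccc(CNCCCNc2ccnc3cc(Cc4ccc(F)cc4)ccc23)c1O` — 23 10^-6 cm/s

In an ADME assay for permeability, using PAMPA, with a stated time of 30 min, at pH 7.4 (on this read-out higher numbers stand for higher permeability and lower numbers for lower permeability), compound 1 stands highest of the two numbers; the nearest, compound 2, lies well below it, a gap beyond the usual scatter. Compound 3 `c1ccc(Cc2ccc3c(NCCCNCc4ccco4)ccnc3c2)cc1` is the next case to be run in this assay, and it differs from compound 1 in one place: benzyl in place of 2-methoxyphenoxy on an aromatic carbon. Among the compounds with values here, no pair of measured compounds shows this change in isolation, so the size of the step rests on expectation alone. Compound 1 already sits near the upper end of what this read-out usually returns, so the expected step from it is small, downward or none beyond the scatter: a 1.6-fold lower number from compound 1 to compound 3 (0.20 log units; within the scatter). Compound 3 is estimated at 200 10^-6 cm/s, with a range from 80 10^-6 cm/s to 500 10^-6 cm/s.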

Compound 3, apparent permeability: 23 10^-6 cm/s
Beside the measured number, compound 3's estimate is 8.7-fold (0.94 log units) above it; measured number below the stated range.
By their numbers in this assay, from the lowest: compounds 2 and 3 (each within the scatter of the next); then compound 1.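

At this aromatic carbon of the shared core, this assay is sensitive to the substituent: benzyl in place of 2-methoxyphenoxy gives a 14-fold lower number from compound 1 to compound 3 (1.14 log units; beyond the scatter). A single change at this position is therefore enough to produce a large step. The group leaving carries 2 hydrogen-bond acceptors and the group entering 0, but nothing measured here accounts for the step.

Which part of 2-methoxyphenoxy matters remains open. Phenoxy or phenylamino at this carbon would bear on that, and the effect of this change on other cores is also unresolved.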